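The source may hold more compounds than are shown below. What is called first, only, known or untested is meant among the compounds shown, and "the series" means these compounds.

Compound 3, with the structure `C=C1C[C@]23C[C@@]1(O)CC[C@H]2c1ccc(O)c(C)c1[C@@H]3Cn1cc(-c2ccc(C)cc2)nn1`, stands at the weak end of what the study shows. In a functional assay on HL-60 cells (Homo sapiens) for cytotoxicity, read by MTT assay, with a stated time of 4 days (a higher number here means a weaker inhibitor, a lower number a stronger inhibitor), compound 3 gives only a limit of the assay, > 20000 nM. Compound 4, with the structure `C=C1C[C@]23C[C@@]1(O)CC[C@H]2c1cc(Br)c(O)c(C)c1[C@@H]3Cn1cc(-c2ccc(C)cc2)nn1`, differs from it in one place: bromo in place of hydrogen on an aromatic carbon. Among the compounds with values here, no measured step isolates this bromo change. Within the data shown here, the one measured step, an at least 2.7-fold lower number from compound 1 to compound 2 (0.43 log units; beyond the scatter), concerns a different position, and compound 1, with the structure `C=C1C[C@]23C[C@@]1(O)CC[C@H]2c1cc(Br)c(O)c(C)c1[C@@H]3Cn1cc(-c2ccccc2)nn1`, already carries the bromo group. In this assay compound 1 gives only a limit, > 20000 nM. Compound 2, with the structure `C=C1C[C@]23C[C@@]1(O)CC[C@H]2c1cc(Br)c(O)c(C)c1[C@@H]3Cn1cc(-c2ccc(C(F)(F)F)cc2)nn1`, gives 7380 nM in this assay. The two limits rest on (the limit of > 20000 nM in this assay, at which 2 of the 3 values shown sit), so compound 1 and compound 3 cannot be ordered against each other, and the bromo group alone has not lifted any compound above that limit. The expected step of a number no higher from compound 3 to compound 4 (the limit leaves the size open) is therefore no change beyond the scatter, with the value for compound 4 estimated at 20000 nM, within 7000 nM to 60000 nM.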

Compound 4, half-maximal inhibitory concentration: > 20000 nM
Compound 4 was reported as a limit (the forecaster's own chance of this, stated with the estimate: 60%); the middle value sits exactly at the limit.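

Compound 4 shows that bromo in place of hydrogen, ortho to a hydroxy group, does not bring a compound with methyl where compound 2 carries trifluoromethyl to a measured value in this assay, and its result is a limit of the assay. With the bromo group present in both, methyl in place of trifluoromethyl gives an at least 2.7-fold higher number from compound 2 to compound 4 (0.43 log units; beyond the scatter). The steps to compound 4 from compound 3 and from compound 1 cannot be read, and compound 2 is the only one of these compounds off the limit: the limit of > 20000 nM in this assay, at which 3 of the 4 values shown sit.

On these data alone, what the bromo group does when trifluoromethyl is present remains open. So does whether a chlorine, a nitrile or a carboxylic acid in the place of trifluoromethyl would also give a measured value in this assay.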